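Ring amine in place of dimethylamino: outlook for compound 4

This account rests on a few compounds, and the source may have more. Where it says the series, first, only, none or still open, it means among the compounds named here.

Compound 1 `CCC(=O)Nc1cccc(Oc2nc(Nc3ccc(N(C)C)cc3OC)ncc2Cl)c1` gives 80.6% in an assay on isolated protein for inhibition of NUAK family SNF1-like kinase 1 (Homo sapiens), read by ADP-Glo, with a stated time of 60 min, tested at 10 uM, in the presence of a further agent that is not named here; a higher number here means more inhibition at the concentration tested (going by the name of the read-out), a lower number less inhibition. On the numbers shown compound 1 stands second highest of three: compound 3 `CCC(=O)Nc1cccc(Oc2nc(Nc3ccc(N(C)C)cc3)ncc2Cl)c1` with 72.6% lies within the scatter of it, as a number 8 percentage points lower from compound 1 to compound 3 (within the scatter) shows, while compound 2 `CCC(=O)Nc1cccc(Oc2nc(Nc3ccc(N4CCN(C)CC4)cc3)ncc2Cl)c1` with 92.9% sits beyond the scatter above it. Compound 4 `CCC(=O)Nc1cccc(Oc2nc(Nc3ccc(N4CCC(C)CC4)cc3OC)ncc2Cl)c1` differs from compound 1 by 4-methylpiperidin-1-yl in place of dimethylamino on an aromatic carbon. The step that bears on this is a number 20.3 percentage points lower from compound 2 to compound 3 (beyond the scatter), where dimethylamino in place of 4-methylpiperazin-1-yl cost a modest amount of inhibition; the step from compound 1 to compound 3 concerns only methoxy and stays within the scatter. Compound 4 runs that kind of change the other way, so a modest rise of a number 6.4 percentage points higher from compound 1 to compound 4 (within the scatter) is expected. Compound 4 is estimated at 87%, with a range of 76% to 96%.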

Compound 4, a percentage reported as inhibition, at one concentration (the size of the read-out at that concentration, not a potency): 9.2%
Compound 4: the middle estimate sits 77.8 percentage points above what was measured, outside the stated range (below it).
By their numbers in this assay, from the lowest: compound 4; then compounds 3 and 1 (each within the scatter of the next); then compound 2.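

In this assay, the step of a number 71.4 percentage points lower from compound 1 to compound 4 (beyond the scatter) shows that this position, meta to a methoxy group, does not accept every larger ring amine. The step of a number 20.3 percentage points lower from compound 2 to compound 3 (beyond the scatter) had put the higher number with the ring amine, but with 4-methylpiperidin-1-yl a six-membered non-aromatic ring alone does not hold inhibition. Nothing shown accounts for this loss. On these data alone, it remains open whether the methoxy group plays a part, since 4-methylpiperazin-1-yl appears only without it. Also open, as far as these compounds go, is how a morpholine ring or an unsubstituted piperidine ring would read at this position.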